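Compound 4: pyridin-2-yl for 3-fluorophenyl

This account rests on a few compounds, and the source may have more. Where it says the series, first, only, none or still open, it means among the compounds named here.

Values measured in a functional assay on HL-60 cells (Homo sapiens) for cytotoxicity, read by CellTiter-Blue, with a stated time of 48 h (on this read-out lower numbers stand for stronger inhibition and higher numbers for weaker inhibition), are as follows:
compound 1 `CCCOC(=O)CC1C(C(=O)OCCC)=C(N)Oc2ccc(-c3cc(OC)cc(OC)c3)cc21` gives 7600 nM
compound 2 `CCCCOC(=O)CC1C(C(=O)OCCCC)=C(N)Oc2ccc(-c3cc(OC)cc(OC)c3)cc21` gives 32000 nM
compound 3 `CCOC(=O)CC1C(C(=O)OCC)=C(N)Oc2ccc(-c3cccc(F)c3)cc21` gives 76400 nM

Compound 3 (76400 nM) has the highest of the three numbers, beyond the scatter of both compound 1 and compound 2. Compound 4 `CCOC(=O)CC1C(C(=O)OCC)=C(N)Oc2ccc(-c3ccccn3)cc21` carries pyridin-2-yl in place of 3-fluorophenyl on an aromatic carbon and keeps the rest of compound 3. Among the measured compounds shown here, no measured pair shows this change in isolation, so the expectation is only a judgement anchored on compound 3 (76400 nM). The estimate implies a 1.3-fold lower number from compound 3 to compound 4 (0.10 log units; within the scatter) in this assay and so no expected step beyond the scatter. Compound 4 is estimated at 60000 nM (expected range 25000 nM to 140000 nM).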

Compound 4, half-maximal inhibitory concentration: 76900 nM
The estimate for compound 4 lay 1.3-fold (0.11 log units) below the measured number; the measured number falls inside the stated range.
By their numbers in this assay, from the lowest: compound 1; then compound 2; then compounds 3 and 4 (each within the scatter of the next).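

In this assay, pyridin-2-yl in place of 3-fluorophenyl on this aromatic carbon gives a 1.0-fold higher number from compound 3 to compound 4 (0.00 log units; within the scatter). At this position, the ring of carbon only bearing fluorine and the ring with one hetero atom and one hydrogen-bond acceptor therefore cannot be told apart. Nothing measured explains this outcome.

Open, on these data alone, is whether pyridin-4-yl, or an amine or carboxylic acid on this ring, would shift the number. Also open, as far as these compounds go, is how the gaps among compound 1, compound 2 and compound 3 divide between the aromatic group and the ester chains.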